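A few compounds are considered here, and "the series" means these few. Any claim that something is new, unique, unknown or untested is made for them only; others in the source may bear on it.

Four compounds that share a common core were examined in a functional assay on A549 cells (Homo sapiens) for inhibition, read by MTT assay, with a stated time of 48 h; on this read-out lower numbers stand for stronger inhibition and higher numbers for weaker inhibition. Compound 1 `Cn1c(=O)[nH]c2nc(SCC(=O)c3ccc(Cl)cc3)[nH]c2c1=O` gives 8100 nM in this assay, and compound 2 `Cn1c(=O)[nH]c2nc(SCC(=O)c3ccc(Br)cc3)[nH]c2c1=O`, which carries the change (bromo in place of chloro on an aromatic carbon), gives 11900 nM; the step between them is a 1.5-fold higher number from compound 1 to compound 2 (0.17 log units; within the scatter). Compound 3 `Cn1c(=O)[nH]c2nc(SC/C(=N/O)c3ccc(Cl)cc3)[nH]c2c1=O` gives 1890 nM, the lowest of the three measured numbers; how its core differs from the core of compound 1 is not broken down here. Compound 4 `Cn1c(=O)[nH]c2nc(SC/C(=N/O)c3ccc(Br)cc3)[nH]c2c1=O` has not yet been measured in this assay. It is related to compound 3 by bromo in place of chloro on an aromatic carbon, which is the same change as that made from compound 1 to compound 2, at the same place; this change occurs twice among these compounds. Among the measured compounds shown here, because the earlier step of a 1.5-fold higher number from compound 1 to compound 2 (0.17 log units; within the scatter) lay within the scatter, compound 4 is expected to give a number close to the one seen for compound 3. For compound 4 the expected step is therefore a 1.3-fold higher number from compound 3 to compound 4 (0.12 log units; within the scatter). The estimate for compound 4 is 2500 nM, expected to fall between 1000 nM and 6500 nM.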

Compound 4, half-maximal inhibitory concentration: 2100 nM
Compound 4: the middle estimate sits 1.2-fold (0.08 log units) above what was measured; low and high end bracket the measured number.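

In this assay the change from 4-chlorophenyl to 4-bromophenyl gives a 1.1-fold higher number from compound 3 to compound 4 (0.05 log units; within the scatter). Set beside the earlier step, the change reads the same on the core of compound 1 and on the core of compound 3, and the two steps do not differ: the same change on two cores in this assay, a 1.5-fold higher number (0.17 log units; within the scatter) from compound 1 to compound 2 and a 1.1-fold higher number (0.05 log units; within the scatter) from compound 3 to compound 4, 1.3-fold (0.12 log units) apart, within the scatter of two such steps

This shows that, in these two pairs, bromo in place of chloro carries over from one core to the other as a step too small to separate the compounds, but it does not show that the same would hold on any further core, and two pairs make no general rule for the series.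

The compounds shown leave open whether other groups at this place, such as fluoro, methoxy or an amine, would move the number on either core, as only the two halogens appear there. Also open, from the compounds shown here alone, is what a longer chain carrying the 4-bromophenyl group would do in this assay.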